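The source may report more compounds than this note shows. Statements on the series, on what has been measured and on what is new or still open speak of the compounds shown alone.

Three close relatives of one scaffold have been tested in an ADME assay on Raji cells (Homo sapiens) for cytotoxicity, read by luminescence, with a stated time of 72 h (a higher number here means that more compound is needed for the effect, a lower number that less compound is needed), and a fourth awaits its turn. Compound 1, `CCOC(=O)c1c(-c2cccc(OC(C)C)c2)[nH]c2cc(OC)ccc2c1=O`, carries an isopropoxy group on one of its two aromatic rings and a methoxy group on the other. In this assay compound 1 reaches only the limit of the measurement, > 21500 nM. Compound 2, `CCOC(=O)c1c(-c2cccc(OC(F)(F)F)c2)[nH]c2cc(OC)ccc2c1=O`, is built from compound 1 by trifluoromethyl in place of isopropyl on an oxygen on an aromatic ring. Compound 2 likewise stops at the limit, > 21500 nM, so the step that the two limits leave unreadable from compound 1 to compound 2 cannot be sized: two limits give no readable difference. Compound 3, `CCOC(=O)c1c(-c2cccc(OC)c2)[nH]c2cc(OC(C)C)ccc2c1=O`, holds the same atoms as compound 1 joined in a different arrangement, the isopropoxy and methoxy groups having traded rings; the difference between the two cores is not broken down here. Compound 3 also sits at the limit, > 21500 nM.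

Compound 4, `CCOC(=O)c1c(-c2cccc(OC)c2)[nH]c2cc(OC(F)(F)F)ccc2c1=O`, follows from compound 3 by trifluoromethyl in place of isopropyl on an oxygen on an aromatic ring, the same change that turns compound 1 into compound 2 and at the same kind of place. For the measured compounds named here, the one piece of evidence available is the limit of > 21500 nM in this assay, at which 3 of the 3 values shown sit, which holds every measured compound at the ceiling of the assay. From compound 3 to compound 4 the step is expected to be a step that the limit leaves unreadable from compound 3 to compound 4, resting on the fact that the parallel change left compound 2 at the same limit as compound 1. The expected outcome for compound 4 is therefore 30000 nM, most likely reported again only as a limit.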

Compound 4, half-maximal effective concentration: > 21500 nM
Compound 4 was reported as a limit; the forecaster's own chance of this, stated with the estimate: 85%; the middle value is on the limit's open side.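

In this assay compound 4 gives only a limit, > 21500 nM. For the compounds shown here, compound 3 also stops at a limit, so no step from compound 3 to compound 4 can be read. Left open is the concentration at which any of these compounds would show the effect, and whether trifluoromethyl in place of isopropyl changes that concentration at all: the limit of > 21500 nM in this assay, at which 4 of the 4 values shown sit.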